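A few compounds are considered here, and "the series" means these few. Any claim that something is new, unique, unknown or untested is made for them only; others in the source may bear on it.

Three compounds have been measured so far:

- Compound 1, `Cc1cccc(S(=O)(=O)Nc2ccc(-c3cccc(Cl)c3)nn2)c1`, gives 101 nM in an assay on mitochondria from liver for inhibition of kynurenine 3-monooxygenase (Mus musculus), read by LC-MS, with stated times of 5 min and 30 min; a higher number here means a weaker inhibitor, a lower number a stronger inhibitor.
- Compound 2, `Cc1ccc(S(=O)(=O)Nc2ccc(-c3ccccc3N(C)C)nn2)cc1`, gives 4.5 nM in this assay.
- Compound 3, `Cc1ccc(S(=O)(=O)Nc2ccc(-c3cccc4ccn(C)c34)nn2)cc1`, gives 29.1 nM in this assay.

Of these three numbers, compound 2 has the lowest, which in this assay means it is the strongest inhibitor of the set. The nearest of the others is compound 3, whose number lies well beyond the scatter above that of compound 2, and compound 1 lies further above still. No two of the three measured compounds differ in only one place, so none of them gives a directly comparable step.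

The next compound to be tested is compound 4, `COc1ccccc1-c1ccc(NS(=O)(=O)c2ccc(C)cc2)nn1`. It is compound 2 with one change: methoxy in place of dimethylamino on an aromatic carbon. Among the compounds with values here, nothing among the measured compounds shows what this particular exchange does. The expectation, resting only on compound 2 and its value 4.5 nM, is a modest move toward a higher number, perhaps at the edge of the scatter. Compound 4 is therefore estimated at 12 nM, with a likely range from 4 nM to 40 nM, meaning an expected step of a 2.7-fold higher number from compound 2 to compound 4 (0.43 log units; beyond the scatter).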

Compound 4, half-maximal inhibitory concentration: 36.5 nM
Estimate against measurement, compound 4: 3.0-fold (0.48 log units) below; the measured number falls inside the stated range.
By their numbers in this assay, from the lowest: compound 2; then compounds 3 and 4 (each within the scatter of the next); then compound 1.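

In this assay the exchange of dimethylamino for methoxy on this aromatic carbon, ortho to a large group, gives an 8.1-fold higher number from compound 2 to compound 4 (0.91 log units; beyond the scatter) and so shows that the number responds to which group sits at this position. The two groups have the same counts of hydrogen-bond donors and acceptors, and neither carries a net charge, so those counts alone do not predict the same number here; they differ in heavy atoms, 3 for dimethylamino and 2 for methoxy, and in having nitrogen or oxygen. No measurement shown here bears on what lies behind this step.

One exchange cannot separate the effect of the atom attached to the ring from that of the size of the group, and a plain amine, a methylamino group, a hydroxyl or an ethoxy group at this place would each speak to that question. Going by these compounds, it also remains open whether methoxy in place of dimethylamino would give a step of similar size with other groups elsewhere on the shared core, since this exchange appears only once.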